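Propoxy to isobutoxy: working notes on compound 4

The source may hold more compounds than are shown below. What is called first, only, known or untested is meant among the compounds shown, and "the series" means these compounds.

In a functional assay on HT-29 cells (Homo sapiens) for cytotoxicity, read by MTT assay (a lower number here means a stronger inhibitor, a higher number a weaker inhibitor), compound 2 `CCCOc1ccc(O)c(C(=O)/C=C/c2ccc(C)s2)c1` gives 126000 nM, within the scatter of compound 3 `CCCCOc1ccc(O)c(C(=O)/C=C/c2ccc(C)s2)c1` at 71400 nM. Compound 1 `CCOc1ccc(OCC)c(C(=O)/C=C/c2ccc(C)s2)c1` gives 3200 nM, a much lower number than either.

Compound 4 `Cc1ccc(/C=C/C(=O)c2cc(OCC(C)C)ccc2O)s1` differs from compound 2 by methyl in place of hydrogen on a saturated chain carbon bound to two saturated chain carbons, which turns propoxy into isobutoxy.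

Within the data shown here, only one measured step bears on this change: a 1.8-fold lower number from compound 2 to compound 3 (0.25 log units; within the scatter). It also places methyl for hydrogen on a saturated chain carbon, but three bonds along the chain from an oxygen on an aromatic ring. One step of this kind is thin evidence, and no branched chain has been measured yet. No shift beyond the scatter is therefore expected. The expected change is a 1.3-fold lower number from compound 2 to compound 4 (0.12 log units; within the scatter). For compound 4 the estimated value is 95000 nM, with an expected range of 40000 nM to 200000 nM.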

Compound 4, half-maximal inhibitory concentration: 30700 nM
Compound 4: middle estimate off by 3.1-fold (0.49 log units), on the high side, outside the stated range (below it).
By their numbers in this assay, from the lowest: compound 1; then compound 4; then compounds 3 and 2 (each within the scatter of the next).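

In this assay, among these compounds, methyl at this position moves the number beyond the scatter (a 4.1-fold lower number from compound 2 to compound 4 (0.61 log units; beyond the scatter)), which the one earlier step on the chain, from propoxy to butoxy, did not do. The placement of the added carbon therefore counts here: isopropyl in place of propyl on a saturated chain carbon bound to an oxygen on an aromatic ring also gives a modest step beyond the scatter (a 2.3-fold lower number from compound 3 to compound 4 (0.37 log units; beyond the scatter)), so among these three compounds the branched chain gives the lowest number. No data shown explain this difference.

Going by these compounds, it remains open whether the trend extends to a longer branched chain such as isopentyloxy or to a more compact one such as cyclopropylmethoxy. On these data alone, how an amine or a carboxylic acid on this chain would read in this assay is also open.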